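Swapping 3-oxopiperazin-1-yl for (2-hydroxyethyl)amino

The compounds below may be only part of what the source reports. "The series", "measured", "known", "first", "only" and "open" are said of these compounds alone.

compound 1 `Clc1nc2c(N3CCCC3)nc(N3CCNCC3)nc2nc1N1CCCC1` gives 3100 nM
compound 2 `CN(C)c1nc2nc(N3CCNCC3)nc(N3CCCC3)c2nc1Cl` gives 5800 nM
compound 3 `O=C1CN(c2nc(N3CCCC3)c3nc(Cl)c(NCc4ccccc4)nc3n2)CCN1` gives 9500 nM

In a functional assay (Homo sapiens) for inhibition, read by sulforhodamine B assay, with a stated time of 3 days (on this read-out lower numbers stand for stronger inhibition and higher numbers for weaker inhibition), compound 3 (9500 nM) cannot be told apart from compound 2 (5800 nM) within the usual scatter, and it is clearly weaker than compound 1 (3100 nM).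

The next compound, compound 4 `OCCNc1nc(N2CCCC2)c2nc(Cl)c(NCc3ccccc3)nc2n1`, carries (2-hydroxyethyl)amino in place of 3-oxopiperazin-1-yl on an aromatic carbon between two ring nitrogen atoms ((2-hydroxyethyl)amino in place of 3-oxopiperazin-1-yl on an aromatic carbon).

Among the compounds with values here, no measured step touches this place. The only one available (a 1.9-fold higher number from compound 1 to compound 2 (0.27 log units; within the scatter)) is a change elsewhere on the core, so it offers just a weak guide: a swap of one group for another that stayed within the scatter. On that thin evidence, no step beyond the scatter is expected in this assay, and the range must stay wide. The estimated step is small (a 1.2-fold lower number from compound 3 to compound 4 (0.07 log units; within the scatter)). For compound 4 the expected value is 8000 nM (estimated range 3000 nM to 20000 nM).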

Compound 4, half-maximal inhibitory concentration: 15200 nM
The estimate for compound 4 lay 1.9-fold (0.28 log units) below the measured number, within the range that was stated.
By their numbers in this assay, from the lowest: compounds 1, 2, 3 and 4 (each within the scatter of the next, the first and the last beyond it).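

Within the data shown here, this is the first measured change at this place, the aromatic carbon between two ring nitrogen atoms. In this assay exchanging 3-oxopiperazin-1-yl, a six-membered non-aromatic ring, for the open-chain (2-hydroxyethyl)amino gives a 1.6-fold higher number from compound 3 to compound 4 (0.20 log units; within the scatter) and so shows that, for this pair, giving up that ring leaves the two numbers indistinguishable. No measurement shown here explains this result.

The compounds shown leave open whether other groups at this place would read differently, for instance a longer chain such as (3-hydroxypropyl)amino or a chain ending in a carboxylic acid. They also leave open whether the same exchange would read alike with different groups elsewhere on the shared core.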